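Aryl in place of cycloalkyl on the shared core

The compounds below may be only part of what the source reports. "The series", "measured", "known", "first", "only" and "open" are said of these compounds alone.

Going by the values given here, compound 1 `CCCCOC(=O)NS(=O)(=O)c1ccc(CCC)cc1-c1ccc(Cn2c(C3CCCC3)nc3ccccc32)cc1` stands highest of the three numbers so far in an assay on membranes from HEK293 cells for displacement of a labelled ligand from Type-2 angiotensin II receptor (Homo sapiens), read by radioligand binding (on this read-out higher numbers stand for weaker inhibition and lower numbers for stronger inhibition), at 35 nM. Compound 2 `CCCCOC(=O)NS(=O)(=O)c1ccc(CCC)cc1-c1ccc(Cn2c(CC)nc3ccccc32)cc1` carries ethyl in place of cyclopentyl on an aromatic carbon; in this assay compound 2 gives 11 nM, a step of a 3.2-fold lower number from compound 1 to compound 2 (0.50 log units; beyond the scatter). Compound 3 `CCCCOC(=O)NS(=O)(=O)c1ccc(CCC)cc1-c1ccc(Cn2c(-c3nccs3)nc3ccccc32)cc1` carries 1,3-thiazol-2-yl on that aromatic carbon; in this assay compound 3 gives 5.1 nM, which is a 6.9-fold lower number from compound 1 to compound 3 (0.84 log units; beyond the scatter), and against the ethyl analogue the step is a 2.2-fold lower number from compound 2 to compound 3 (0.33 log units; beyond the scatter).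

Compound 4 `CCCCOC(=O)NS(=O)(=O)c1ccc(CCC)cc1-c1ccc(Cn2c(-c3ccccc3)nc3ccccc32)cc1` is the next point in the series. The change from compound 1 is phenyl in place of cyclopentyl on an aromatic carbon. Both replacements of cyclopentyl recorded so far lowered the number beyond the scatter, and the aromatic one in compound 3 did so more than the ethyl one in compound 2, so a lower number is expected for compound 4 as well, plausibly of a size bracketed by those two steps. Compound 4 is therefore expected to give about 8 nM in this assay, with a range from 3 nM to 25 nM, corresponding to an expected step of a 4.4-fold lower number from compound 1 to compound 4 (0.64 log units; beyond the scatter).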

Compound 4, inhibition constant: 590 nM
Beside the measured number, compound 4's estimate is 74-fold (1.87 log units) below it; measured number above the stated range.
By their numbers in this assay, from the lowest: compound 3; then compound 2; then compound 1; then compound 4.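

In this assay the group on this aromatic carbon, between two ring nitrogen atoms, is not sorted by aromatic versus non-aromatic: the two aromatic rings lie at opposite ends of the series, with a 120-fold higher number from compound 3 to compound 4 (2.06 log units; beyond the scatter) on going from 1,3-thiazol-2-yl to phenyl. Compound 4 goes against the earlier pattern in which replacing cyclopentyl lowered the number, showing a 17-fold higher number from compound 1 to compound 4 (1.23 log units; beyond the scatter) even though phenyl and cyclopentyl are both carbon-only rings with no hydrogen-bond donors or acceptors, and ethyl also compares favourably, with a 54-fold higher number from compound 2 to compound 4 (1.73 log units; beyond the scatter) on going to phenyl. The data at hand offer no explanation for the separation of phenyl from 1,3-thiazol-2-yl or from the non-aromatic groups.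

Still open, on these data alone, is whether other aromatic rings, such as pyridyl or furyl, would track with 1,3-thiazol-2-yl or with phenyl on this carbon. Also open, as far as these compounds go, is how a longer chain than ethyl, a cyclopropyl ring or a benzyl group would stand against cyclopentyl on the shared core.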